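The source may report more compounds than this note shows. Statements on the series, on what has been measured and on what is new or still open speak of the compounds shown alone.

Compound 1 `O=c1nc2oc(C3CC3)c(C#CC3CC3)c2cn1Cc1cn(Cc2ccccc2)nn1` gives 290 nM in an ADME assay on WI-38 cells (Homo sapiens) for antiproliferative activity, read by MTT assay, with a stated time of 72 h; on this read-out lower numbers stand for stronger inhibition and higher numbers for weaker inhibition.
Compound 2 `CCCCCCc1cc2cn(Cc3cn(Cc4ccccc4)nn3)c(=O)nc2o1` gives 62800 nM in this assay.
Compound 3 `O=c1nc2oc(C3CC3)cc2cn1Cc1cn(-c2ccc(Cl)cc2)nn1` gives only a limit, > 100000 nM, in this assay.

Within the data shown here, compound 3 thus stands at the limit of > 100000 nM in this assay, at which 1 of the 3 values shown sits; the assay reports no number for it, so its distance from compound 1 and from compound 2 cannot be put into figures, and no pair of the three measured compounds differs in a single place that would give a step to lean on.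

The compound that follows, compound 4 `O=c1nc2oc(C3CC3)cc2cn1Cc1cn(Cc2ccccc2)nn1`, keeps the whole of compound 3 except for one change: benzyl in place of 4-chlorophenyl on an aromatic nitrogen. The benzyl group is the one carried on that ring nitrogen by compound 1 and by compound 2, both of which return numbers rather than a limit, although each of them also differs from compound 4 elsewhere in the core, so their values span a wide range and fix little. On that footing the step from compound 3 to compound 4 is expected to be one beyond the scatter, toward stronger inhibition, an at least 5.0-fold lower number from compound 3 to compound 4 (0.69 log units; beyond the scatter). Compound 4 is accordingly estimated at 20000 nM, with a likely range from 2000 nM to 100000 nM.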

Compound 4, half-maximal inhibitory concentration: 29700 nM
Compound 4: the middle estimate sits 1.5-fold (0.17 log units) below what was measured; measured number inside the range.
By their numbers in this assay, from the lowest: compound 1; then compound 4; then compound 2. At a limit, above all of these: compound 3.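

In this assay, among these compounds, benzyl in place of 4-chlorophenyl on an aromatic nitrogen of the five-membered ring gives an at least 3.3-fold lower number from compound 3 to compound 4 (0.52 log units; beyond the scatter) and so provides the first step at this position, though it brings compound 4 only to the weak end of the series. Compound 3 is held at a limit and not at a number, so this step has only a lower bound: the limit of > 100000 nM in this assay, at which 1 of the 4 values shown sits. With benzyl kept on that nitrogen, the aromatic carbon of the core counts for far more, as the loss of 2-cyclopropylethynyl gives a 100-fold higher number from compound 1 to compound 4 (2.01 log units; beyond the scatter) while cyclopropyl in place of hexyl gives only a 2.1-fold lower number from compound 2 to compound 4 (0.33 log units; beyond the scatter) on that same core.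

Going by these compounds, the full size of the step at the nitrogen stays open, and it rests on a single pair of compounds that lacks 2-cyclopropylethynyl, so whether benzyl would keep its advantage over 4-chlorophenyl with that group present is unknown. On these data alone, how a plain phenyl, a longer chain or an amine-bearing chain on that nitrogen would read in this assay also remains open.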